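Swapping the 3-phenylphenyl group in compound 3 for 2,4-difluorophenyl

The source may hold more compounds than are shown below. What is called first, only, known or untested is meant among the compounds shown, and "the series" means these compounds.

In a toxicity assay on NIH3T3 cells (Mus musculus) for cytotoxicity, read by resazurin assay (a higher number here means that more compound is needed for the effect, a lower number that less compound is needed), compound 1 `COC(=O)c1ccc(NCc2cncn2Cc2ccccc2)cc1-c1ccccc1` gives > 1000 nM, which is a limit of the assay and not a number. Compound 2 `COC(=O)c1ccc(NCc2cncn2Cc2ccccc2Br)cc1-c1ccccc1`, with bromo in place of hydrogen on an aromatic carbon, gives 10000 nM. Among the measured compounds shown here, this is the only measured step, a step that the limit leaves unreadable from compound 1 to compound 2, so it offers no size to carry forward. Compound 3 `COC(=O)c1ccc(NCc2cncn2Cc2cccc(-c3ccccc3)c2)cc1-c1ccccc1` stands without a number, as its result reads "not determined" (no result reported). Compound 4 `COC(=O)c1ccc(NCc2cncn2Cc2ccc(F)cc2F)cc1-c1ccccc1` differs from compound 3 by 2,4-difluorophenyl in place of 3-phenylphenyl on a saturated chain carbon bound to an aromatic nitrogen, with 2,4-difluorophenyl in place of 3-phenylphenyl on a saturated chain carbon bound to an aromatic nitrogen. With no starting value and no readable step, neither a size nor a direction can be expected for this change in this assay. For the measured compounds named here, the estimate therefore rests on the single firm number, the one for compound 2 at 10000 nM, and its range is kept wide. Compound 4 is expected near 8000 nM, with an estimated range from 2000 nM to 30000 nM.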

Compound 4, half-maximal effective concentration: > 1000 nM
Compound 4 ended at the assay's limit; the forecaster's own chance of this, stated with the estimate: 35%; the middle value does not contradict the limit.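

In this assay compound 4 gives > 1000 nM, which is a limit of the assay and not a number. The steps to compound 4 from compound 1 and compound 2 cannot be read: the limit of > 1000 nM in this assay, at which 2 of the 4 values shown sit. The compounds shown leave open whether phenyl, 2-bromophenyl and 2,4-difluorophenyl truly differ here.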